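This account rests on a few compounds, and the source may have more. Where it says the series, first, only, none or still open, it means among the compounds named here.

Compound 1 `COC(=O)CNC1=CS(=O)(=O)O[C@@]12[C@@H](CO[Si](C)(C)C(C)(C)C)O[C@@H](n1cc(C)c(=O)n(C)c1=O)[C@@H]2O[Si](C)(C)C(C)(C)C`: 96000 nM; compound 2 `Cc1cn([C@@H]2O[C@H](CO[Si](C)(C)C(C)(C)C)[C@@]3(OS(=O)(=O)C=C3NCC(=O)C(N)=O)[C@H]2O[Si](C)(C)C(C)(C)C)c(=O)n(C)c1=O`: 9960 nM; compound 3 `Cc1cn([C@@H]2O[C@H](CO[Si](C)(C)C(C)(C)C)[C@@]3(OS(=O)(=O)C=C3NCC(=O)C(=O)N3CCC3)[C@H]2O[Si](C)(C)C(C)(C)C)c(=O)n(C)c1=O`: 21600 nM. All three were measured in a functional assay on CCRF-CEM cells (Homo sapiens); on this read-out higher numbers stand for lower toxicity in this test and lower numbers for higher toxicity in this test.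

Among these three, compound 3 stands second highest; its nearest neighbour is given by a 2.2-fold higher number from compound 2 to compound 3 (0.34 log units; beyond the scatter) and its furthest by a 4.4-fold lower number from compound 1 to compound 3 (0.65 log units; beyond the scatter).

Compound 4 `COC(=O)NC1=CS(=O)(=O)O[C@@]12[C@@H](CO[Si](C)(C)C(C)(C)C)O[C@@H](n1cc(C)c(=O)n(C)c1=O)[C@@H]2O[Si](C)(C)C(C)(C)C` differs from compound 3 in one place: methoxycarbonyl in place of (((azetidin-1-yl)carbonyl)carbonyl)methyl on an amine nitrogen. Among the compounds with values here, no measured pair covers this exact change. The steps of a 9.6-fold lower number from compound 1 to compound 2 (0.98 log units; beyond the scatter) and a 4.4-fold lower number from compound 1 to compound 3 (0.65 log units; beyond the scatter) show that exchanging methoxy on a carbonyl carbon for carbamoyl or (azetidin-1-yl)carbonyl lowered the number by modest amounts. Compound 4 brings a methoxycarbonyl back, now on the amine nitrogen, so the number is expected to move back toward compound 1. The expected step is a 3.2-fold higher number from compound 3 to compound 4 (0.51 log units; beyond the scatter). For compound 4 the estimate in this assay is 70000 nM, ranging from 20000 nM to 200000 nM.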

Compound 4, half-maximal cytotoxic concentration: 30700 nM
Beside the measured number, compound 4's estimate is 2.3-fold (0.36 log units) above it; the range from low to high includes it.
By their numbers in this assay, from the lowest: compound 2; then compounds 3 and 4 (each within the scatter of the next); then compound 1.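

In this assay, methoxycarbonyl set directly on the amine nitrogen does not match the (methoxycarbonyl)methyl group, giving a 3.1-fold lower number from compound 1 to compound 4 (0.50 log units; beyond the scatter) as a modest step. It also stands apart from (carbamoylcarbonyl)methyl, with a 3.1-fold higher number from compound 2 to compound 4 (0.49 log units; beyond the scatter) on that side, while a 1.4-fold higher number from compound 3 to compound 4 (0.15 log units; within the scatter) leaves it indistinguishable from (((azetidin-1-yl)carbonyl)carbonyl)methyl. The data offer no explanation for these differences. The compounds shown leave open how a carboxylic acid or an amine at the end of a longer chain on this nitrogen would read in this test.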